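Second Demethylation on a Shared Core

A few compounds are considered here, and "the series" means these few. Any claim that something is new, unique, unknown or untested is made for them only; others in the source may bear on it.

Compound 1 `COC1=C(OC)[C@@]2(OC)c3c(OC)c(OC)c4c(c3O[C@@]23O[C@@H](c2ccccc2)CC=C3C1=O)[C@@H](OC)C[C@H](c1ccccc1)O4` and compound 2 `COC1=C(OC)[C@@]2(OC)c3c(O)c(OC)c4c(c3O[C@@]23O[C@@H](c2ccccc2)CC=C3C1=O)[C@@H](OC)C[C@H](c1ccccc1)O4` have been measured in a functional assay on BC1 cells (Homo sapiens) for cytotoxicity against BC1 cell line; on this read-out higher numbers stand for an effect only at larger amounts of compound and lower numbers for an effect already at smaller amounts. Compound 1 gives 0.4 ug/mL in this assay, and compound 2 gives 5.4 ug/mL, the highest of the two numbers; the step from the first to the second is a 14-fold higher number from compound 1 to compound 2 (1.13 log units; beyond the scatter). Compound 3 `COC1=C(OC)[C@@]2(OC)c3c(O)c(OC)c4c(c3O[C@@]23O[C@@H](c2ccccc2)CC=C3C1=O)[C@@H](O)C[C@H](c1ccccc1)O4` is not yet measured. It differs from compound 2 by hydrogen in place of methyl on an oxygen on a saturated carbon. Within the data shown here, the only measured step, a 14-fold higher number from compound 1 to compound 2 (1.13 log units; beyond the scatter), concerns the same exchange at another place, on an oxygen on an aromatic ring, so it bears on the new step only loosely. A further step in the same direction is expected for compound 3, but smaller than the measured one, estimated as a 1.9-fold higher number from compound 2 to compound 3 (0.27 log units; within the scatter) in this assay. Compound 3 is therefore expected to give about 10 ug/mL in this assay, within a range from 3 ug/mL to 30 ug/mL.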

Compound 3, half-maximal effective concentration: 1.4 ug/mL
Estimate against measurement, compound 3: 7.1-fold (0.85 log units) above; measured number below the stated range.
By their numbers in this assay, from the lowest: compound 1; then compound 3; then compound 2.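

In this assay the change from methoxy to hydroxy on an oxygen on a saturated carbon gives a 3.9-fold lower number from compound 2 to compound 3 (0.59 log units; beyond the scatter) and so runs opposite to the same exchange on an oxygen on an aromatic ring, which gave a 14-fold higher number from compound 1 to compound 2 (1.13 log units; beyond the scatter) in the earlier pair. The direction of this exchange therefore depends on where it is made on the shared core, something a single step could not show, and the number moves less at the saturated carbon than at the aromatic ring. Nothing available explains why the two places differ.

Still open, going by these compounds, is whether an amine or a longer chain such as ethoxy on this saturated carbon would lower the number further or raise it. On these data alone, it is also open whether the hydroxy here would give a step of similar size and direction on the core of compound 1, where the aromatic methoxy remains.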